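A few compounds are considered here, and "the series" means these few. Any claim that something is new, unique, unknown or untested is made for them only; others in the source may bear on it.

Compound 1 `Cc1cc(Nc2cc(N3CCN(C)CC3)nc(Nc3ccc(F)cc3)n2)n[nH]1` gives 255 nM in a functional assay on MDA-MB-231 cells (Homo sapiens) for antiproliferative activity, read by CCK-8 assay, with a stated time of 48 h; on this read-out lower numbers stand for stronger inhibition and higher numbers for weaker inhibition. For the measured compounds named here, compound 2 `COc1ccc(Nc2nc(Nc3cc(C)[nH]n3)cc(N3CCN(C)CC3)n2)cc1OC`, in this assay, gives 459 nM, a change of a 1.8-fold higher number from compound 1 to compound 2 (0.26 log units; within the scatter), so the two numbers sit within the scatter of each other and compound 2 stands level with the only other measured compound. Compound 3 `Cc1cc(Nc2cc(N3CCN(C)CC3)nc(Nc3ccc(Cl)c(F)c3)n2)n[nH]1` differs from compound 2 by 4-chloro-3-fluorophenyl in place of 3,4-dimethoxyphenyl on a nitrogen on an aromatic ring. Going by the values given here, the one step that bears on it, an exchange of the same aryl group, stayed within the scatter, so a step of similar size, a 1.4-fold lower number from compound 2 to compound 3 (0.16 log units; within the scatter), is expected, none beyond the scatter. Compound 3 is expected to give about 320 nM, between 120 nM and 850 nM.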

Compound 3, half-maximal inhibitory concentration: 155 nM
Estimate against measurement, compound 3: 2.1-fold (0.31 log units) above, and the stated range covers the measured number.
By their numbers in this assay, from the lowest: compounds 3, 1 and 2 (each within the scatter of the next, the first and the last beyond it).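

For the compounds shown here, putting 4-chloro-3-fluorophenyl in place of 3,4-dimethoxyphenyl on this nitrogen gives a 3.0-fold lower number from compound 2 to compound 3 (0.47 log units; beyond the scatter) and is the only step here that clears the scatter, so the aryl group at this position can shift the number. Against 4-fluorophenyl, the same group gives a 1.6-fold lower number from compound 1 to compound 3 (0.22 log units; within the scatter) and so stands level with it. No measurement at hand explains the difference between compound 2 and compound 3.

From the compounds shown here alone, whether the chlorine or the fluorine of compound 3 counts for more stays open. So does the outcome with a nitrile or trifluoromethyl group on the phenyl ring.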